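Cycloheptyl on the Ring Nitrogen of Compound 4

The source may report more compounds than this note shows. Statements on the series, on what has been measured and on what is new or still open speak of the compounds shown alone.

Compound 1 `CC(C)N1CCN(Cc2csc(N)c2C(=O)c2ccc(Cl)cc2)CC1`: -1%
Compound 2 `Nc1scc(CN2CCN(c3ccc([N+](=O)[O-])cc3)CC2)c1C(=O)c1ccc(Cl)cc1`: -12%
Compound 3 `Nc1scc(CN2CCN(c3ccccc3C(F)(F)F)CC2)c1C(=O)c1ccc(Cl)cc1`: 0%

The three measured compounds share one core and differ only in the group on an amine nitrogen in a ring. In a functional assay on CHO cells with adenosine receptor A1 (Homo sapiens) as the target, read by cAMP accumulation and immunoassay, with a stated time of 6 min, tested at 0.01 uM (a higher number here means a weaker effect of the compound at the concentration tested, a lower number a stronger effect), compound 3 gives 0%, the highest of the three numbers; it lies within the scatter of compound 1 and beyond the scatter of compound 2, as the steps of a number 1 percentage points higher from compound 1 to compound 3 (within the scatter) and a number 12 percentage points higher from compound 2 to compound 3 (beyond the scatter) show. Compound 4 `Nc1scc(CN2CCN(C3CCCCCC3)CC2)c1C(=O)c1ccc(Cl)cc1` carries cycloheptyl in place of 2-(trifluoromethyl)phenyl on an amine nitrogen in a ring. The step that bears most on this is a number 1 percentage points higher from compound 1 to compound 3 (within the scatter): exchanging the isopropyl of compound 1 for the aromatic group of compound 3 moved the number no further than the scatter, so the return to a saturated carbon ring, here a seven-membered one, is expected to leave the number where compound 3 and compound 1 already sit. The step of compound 2 points the other way but concerns a nitrophenyl group that compound 4 does not carry. Compound 4 is therefore expected to show no change at the digits printed from compound 3 to compound 4 (within the scatter), with an estimate of 0% (range -12% to 12%).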

Compound 4, a percentage reported as activity, at one concentration (the size of the read-out at that concentration, not a potency): 2.9%
Beside the measured number, compound 4's estimate is 2.9 percentage points below it; the measured number falls inside the stated range.
By their numbers in this assay, from the lowest: compound 2; then compounds 1, 3 and 4 (each within the scatter of the next).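

In this assay, cycloheptyl on the amine nitrogen in a ring gives a number 2.9 percentage points higher from compound 3 to compound 4 (within the scatter) and a number 3.9 percentage points higher from compound 1 to compound 4 (within the scatter), so a seven-membered non-aromatic carbon ring now joins isopropyl and 2-(trifluoromethyl)phenyl among the groups that cannot be told apart at this position. The 4-nitrophenyl group of compound 2 goes against this shared level, with a number 14.9 percentage points higher from compound 2 to compound 4 (beyond the scatter), and the new compound widens the set from which compound 2 is separated without changing that separation's place in the series. Nothing available explains why the 4-nitrophenyl group alone stands apart.

The compounds shown leave open whether an unsubstituted phenyl or a 4-aminophenyl group at this nitrogen would stand with compound 2 or with the other three. They also leave open whether a carboxylic acid on a longer chain there would move the number at all.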